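Larger aryl substituent tested in a cytotoxicity series

The source may report more compounds than this note shows. Statements on the series, on what has been measured and on what is new or still open speak of the compounds shown alone.

Measured so far:
- compound 1, `Cn1ccc2c(Oc3ccc(NC(=O)c4nn(-c5ccc(Cl)cc5)ccc4=O)cc3F)ccnc21`: > 60000 nM
- compound 2, `COc1ccc(-n2ccc(=O)c(C(=O)Nc3ccc(Oc4ccnc5c4ccn5C)c(F)c3)n2)cc1`: > 60000 nM
- compound 3, `Cn1ccc2c(Oc3ccc(NC(=O)c4nn(-c5ccccc5)ccc4=O)cc3F)ccnc21`: > 60000 nM

The read-out throughout is a functional assay on MCF7 cells (Homo sapiens) for cytotoxicity, read by MTT assay, with a stated time of 72 h; on this read-out lower numbers stand for stronger inhibition and higher numbers for weaker inhibition. For compound 3 the value of > 60000 nM is a limit of this assay, not a number. The same holds for compound 1, whose > 60000 nM is a limit, and for compound 2, whose > 60000 nM is a limit. Accordingly the three measured steps, a step that the two limits leave unreadable from compound 1 to compound 2, a step that the two limits leave unreadable from compound 1 to compound 3 and a step that the two limits leave unreadable from compound 2 to compound 3, cannot be read in size, since (the limit of > 60000 nM in this assay, at which 3 of the 3 values shown sit).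

Compound 4, `Cn1ccc2c(Oc3ccc(NC(=O)c4nn(-c5ccc(Cl)c(C(F)(F)F)c5)ccc4=O)cc3F)ccnc21`, differs from compound 3 by the change (4-chloro-3-(trifluoromethyl)phenyl in place of phenyl on an aromatic nitrogen). Within the data shown here, none of the measured steps changes this part of the molecule in the same way, and each of them is unreadable, so they give no sign of a step in either direction for this assay. Compound 4 is therefore expected to give about 40000 nM, in a range from 8000 nM to 200000 nM. This estimate means a step of an at least 1.5-fold lower number from compound 3 to compound 4 (0.17 log units; that floor lies within the scatter), with a high chance that only a limit is reported again.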

Compound 4, half-maximal inhibitory concentration: 18400 nM
Estimate against measurement, compound 4: 2.2-fold (0.34 log units) above; measured number inside the range.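

In this assay, the steps among compound 1, compound 2 and compound 3 cannot be read, and compound 4 is the only one of the four with a number rather than a limit: the limit of > 60000 nM in this assay, at which 3 of the 4 values shown sit. On this aromatic nitrogen, 4-chloro-3-(trifluoromethyl)phenyl gives an at least 3.2-fold lower number from compound 3 to compound 4 (0.51 log units; beyond the scatter) when it replaces phenyl, and an at least 3.2-fold lower number from compound 2 to compound 4 (0.51 log units; beyond the scatter) when it replaces 4-methoxyphenyl. Adding trifluoromethyl in place of hydrogen to the chloro-bearing aryl group gives an at least 3.2-fold lower number from compound 1 to compound 4 (0.51 log units; beyond the scatter), a single-place change that shows this aryl group can affect the read-out.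

Going by these compounds, the true size of each step stays open, as each one starts from a limit. Also open, on these data alone, are whether trifluoromethyl would do the same without the chloro, and how an amine or a carboxylic acid on this aryl ring would compare.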